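The source may hold more compounds than are shown below. What is called first, only, known or untested is meant among the compounds shown, and "the series" means these compounds.

Compound 2, `CCOC(=O)CCCCCOc1cccc(CN(C(=O)c2ccc(-c3cccc(OC(F)(F)F)c3)cc2)C(C)C)c1`, was examined in an ADME assay on BJ cells (Homo sapiens) for cytotoxicity, read by CellTiter-Glo and resazurin assay, with a stated time of 72 h; on this read-out higher numbers stand for an effect only at larger amounts of compound and lower numbers for an effect already at smaller amounts. In this assay compound 2 gave no number but only the limit > 26000 nM. Its close relative compound 1, `CCOC(=O)CCCCCOc1cccc(CN(C(=O)c2ccc(-c3cccc(OCC)c3)cc2)C(C)C)c1`, which carries ethyl where compound 2 carries trifluoromethyl on an oxygen on an aromatic ring, also stopped at a limit; in this assay compound 1 gave > 22300 nM. For the measured compounds named here, the one measured step, a step that the two limits leave unreadable from compound 1 to compound 2, is unreadable, as both the limit of > 22300 nM in this assay, at which 1 of the 2 values shown sits, and the limit of > 26000 nM in this assay, at which 1 of the 2 values shown sits, show. So far, then, no compound in this series has produced a number, and the step between the two measured compounds gives no size at all.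

Compound 3, `CCOC(=O)CCCCCOc1cccc(CN(C(=O)c2ccc(-c3cccc([N+](=O)[O-])c3)cc2)C(C)C)c1`, differs from compound 2 by nitro in place of trifluoromethoxy on an aromatic carbon. Going by the values given here, no measured step carries this change, and the single measured step offers no size to lean on. Compound 3 is therefore expected to sit where compound 2 sits, with an expected step that the limit leaves unreadable from compound 2 to compound 3 in this assay. The estimate for compound 3 in this assay is 30000 nM, with a range from 10000 nM to 100000 nM.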

Compound 3, half-maximal effective concentration: < 1.3 nM
Compound 3: a limit, no number; the forecaster's own chance of this, stated with the estimate: 80%; middle value at least 23000-fold (4.36 log units) from the limit.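

In this assay, for the compounds shown here, the place on the aromatic ring meta to a large group proves not to be indifferent to what it carries: nitro there gives the first readable changes, an at least 20000-fold lower number from compound 2 to compound 3 (4.30 log units; beyond the scatter) and an at least 17000-fold lower number from compound 1 to compound 3 (4.23 log units; beyond the scatter). Both steps lie beyond the usual scatter and are large, so a single group at this place can separate a compound that shows cytotoxicity in these cells only at large amounts from one that shows it at very small amounts. The reading for compound 3 is itself a limit and not a number: the limit of < 1.3 nM in this assay, at which 1 of the 3 values shown sits.

The compounds shown do not tell whether this effect belongs to nitro alone or would also appear with a nitrile or an amine at the same place. They also leave open how far the effect depends on the rest of the molecule, for instance on the ethyl ester, in whose place a carboxylic acid could stand.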